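Swapping Phenyl for Thiophene on a Fatty Acid Receptor Agonist

This account rests on a few compounds, and the source may have more. Where it says the series, first, only, none or still open, it means among the compounds named here.

Of the compounds shown here, two have been measured in a functional assay on CHO cells for agonist activity at Free fatty acid receptor 1 (Homo sapiens), read by FLIPR and calcium flux, in the presence of a further agent that is not named here; a lower number here means that less compound is needed, a higher number that more compound is needed for the effect. Compound 1 `CC(Oc1ccc(CCC(=O)O)cc1)c1nc(-c2cccs2)no1` gives 4000 nM in this assay. Compound 2 `O=C(O)CCc1ccc(OCc2nc(-c3ccccc3)no2)cc1` gives 1130 nM, the lowest of the two numbers, and the gap to compound 1 is beyond the usual scatter. Compound 1 and compound 2 differ in more than one place, so no single change can be tied to that gap.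

Compound 3 `O=C(O)CCc1ccc(OCc2nc(-c3cccs3)no2)cc1` keeps everything of compound 2 apart from one exchange: thiophen-2-yl in place of phenyl on an aromatic carbon. The acid chain and the rest of the core stay unchanged.

Within the data shown here, no step of this kind has been measured here. Compound 1 also carries thiophen-2-yl and gives the higher number, but it differs from compound 2 in a second place too, so it is only a weak hint. Compound 3 is therefore expected to give about 1800 nM, with a likely range from 600 nM to 5400 nM. That amounts to an expected step of a 1.6-fold higher number from compound 2 to compound 3 (0.20 log units; within the scatter), roughly the size of ordinary scatter, toward a slightly higher number.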

Compound 3, half-maximal effective concentration: 2570 nM
The estimate for compound 3 lay 1.4-fold (0.15 log units) below the measured number; the range from low to high includes it.
By their numbers in this assay, from the lowest: compound 2; then compounds 3 and 1 (each within the scatter of the next).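

Among these compounds, on an aromatic carbon between two ring nitrogen atoms, thiophen-2-yl does not simply match phenyl: in this assay the exchange gives a 2.3-fold higher number from compound 2 to compound 3 (0.36 log units; beyond the scatter), a modest step, but the first reading of this change on its own. With thiophen-2-yl in place, hydrogen and methyl on the saturated chain carbon cannot be told apart, as a 1.6-fold lower number from compound 1 to compound 3 (0.19 log units; within the scatter) stays within the scatter. No measurement at hand explains either step.

On these data alone, whether a furan-2-yl or pyridin-2-yl group at this position would give a number closer to that of phenyl or of thiophen-2-yl remains open. Also open, as far as these compounds go, is what methyl on the saturated chain carbon would do with phenyl kept in place, where the thiophen-2-yl result may not carry over.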